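The compounds below may be only part of what the source reports. "The series", "measured", "known", "first", "only" and "open" are said of these compounds alone.

Measured so far in an assay on cells for inhibition of Amine oxidase [flavin-containing] B (Homo sapiens), read by fluorescence and Amplex Red, with a stated time of 15 min; a higher number here means a weaker inhibitor, a lower number a stronger inhibitor:
compound 1, `Cc1ccc2cc(-c3ccc(Br)nn3)c(=O)oc2c1`, gives 750 nM
compound 2, `Cc1cccc2cc(-c3ccc(Br)nn3)c(=O)oc12`, gives 2640 nM
compound 3, `Cc1ccc2cc(-c3ccc(Cl)nn3)c(=O)oc2c1`, gives 2510 nM

Compound 1 and compound 2 are built from the same atoms joined differently; the difference between the two cores is not broken down here. From compound 1 to compound 3 the change is chloro in place of bromo on an aromatic carbon, and in this assay it made a 3.3-fold higher number from compound 1 to compound 3 (0.52 log units; beyond the scatter). Compound 2 and compound 3 give numbers that lie within the scatter of each other.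

Compound 4, `Cc1cccc2cc(-c3ccc(Cl)nn3)c(=O)oc12`, has not yet been measured in this assay. It differs from compound 2 by chloro in place of bromo on an aromatic carbon, the same change as from compound 1 to compound 3, at a place described in the same words. Resting on the step seen from compound 1 to compound 3, compound 4 is expected to show a step of similar size, a 2.8-fold higher number from compound 2 to compound 4 (0.45 log units; beyond the scatter). Compound 4 is therefore estimated at 7500 nM in this assay, expected to fall between 3000 nM and 18000 nM.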

Compound 4, half-maximal inhibitory concentration: 22700 nM
Beside the measured number, compound 4's estimate is 3.0-fold (0.48 log units) below it; measured number above the stated range.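

In this assay, chloro in place of bromo on an aromatic carbon gave an 8.6-fold higher number from compound 2 to compound 4 (0.93 log units; beyond the scatter) on the second core, the same direction as on the first. The two steps do not differ by more than the scatter of two such steps allows: the same change on two cores in this assay, a 3.3-fold higher number (0.52 log units; beyond the scatter) from compound 1 to compound 3 and an 8.6-fold higher number (0.93 log units; beyond the scatter) from compound 2 to compound 4, 2.6-fold (0.41 log units) apart, within the scatter of two such steps. The change therefore carried across these two cores in direction and, within that scatter, in size, but two pairs do not show that it would hold on any further core in the series, nor why bromo gives the lower number.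

The compounds shown carry only bromo or chloro at this carbon, so what an amine, a nitrile or a methoxy group would do there remains open. Also open, from the compounds shown here alone, is how the core would respond with its methyl group replaced by a longer chain.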